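Sulfonamide Analogues Tested for Cytotoxicity on Prostate Cancer Cells

A few compounds are considered here, and "the series" means these few. Any claim that something is new, unique, unknown or untested is made for them only; others in the source may bear on it.

Measured compounds:
compound 1, `COc1cc(OC)c(/C=C/S(=O)(=O)Nc2ccc(OC)c([N+](=O)[O-])c2)c(OC)c1`: 2500 nM
compound 2, `COC(=O)C(Nc1cc(NS(=O)(=O)/C=C/c2c(OC)cc(OC)cc2OC)ccc1OC)c1ccc(F)cc1`: 2500 nM

Both compounds were tested in a functional assay on DU-145 cells (Homo sapiens) for cytotoxicity, read by trypan blue exclusion, with a stated time of 96 h; a higher number here means a weaker inhibitor, a lower number a stronger inhibitor. On the numbers shown, compound 2 stands level with compound 1: in this assay compound 2 gives 2500 nM and compound 1 gives 2500 nM, which is no change at the digits shown and lies within the usual scatter of repeated runs. For the measured compounds named here, no two measured compounds differ in only one place, so no single step between measured compounds is available as a guide.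

Compound 3, `COc1cc(OC)c(/C=C/S(=O)(=O)Nc2ccc(OC)c(NC(C(=O)O)c3ccc(Br)cc3)c2)c(OC)c1`, has not yet been measured. It differs from compound 2 in one place: (4-bromophenyl)(carboxy)methyl in place of (4-fluorophenyl)(methoxycarbonyl)methyl on a nitrogen on an aromatic ring.

Without a measured step of this kind, there is nothing in the data to point to a large change in either direction. The expectation for compound 3 rests only on compound 2, whose value of 2500 nM in this assay serves as the anchor. The estimated step from compound 2 to compound 3 is a 1.4-fold higher number from compound 2 to compound 3 (0.15 log units; within the scatter), which is expected to lie within the scatter or to amount to a slight weakening at most. Compound 3 is estimated to give 3500 nM in this assay, with a range from 1000 nM to 12000 nM.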

Compound 3, half-maximal inhibitory concentration: 250 nM
Compound 3: the middle estimate sits 14-fold (1.15 log units) above what was measured; the measured number lies below the stated range.
By their numbers in this assay, from the lowest: compound 3; then compounds 1 and 2 (each within the scatter of the next).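

In this assay, the group on a nitrogen on an aromatic ring can clearly move the result: (4-bromophenyl)(carboxy)methyl in place of (4-fluorophenyl)(methoxycarbonyl)methyl gives a 10-fold lower number from compound 2 to compound 3 (1.00 log units; beyond the scatter), a change the two earlier compounds, level with each other, gave no sign of. The same group also stands up against the simple nitro group of the core, since ((4-bromophenyl)(carboxy)methyl)amino in place of nitro on an aromatic carbon gives a 10-fold lower number from compound 1 to compound 3 (1.00 log units; beyond the scatter) and both routes arrive at the same lower number. Nothing measured here accounts for this gain in terms of any property of the groups.

The step from compound 2 to compound 3 changes two things at once, the fluorine to bromine and the methyl ester to a carboxylic acid, so the compounds shown cannot tell which of the two carries the change. A (4-fluorophenyl)(carboxy)methyl group or a (4-bromophenyl)(methoxycarbonyl)methyl group on the same nitrogen would separate them, and a plain amine in place of nitro would show what the nitrogen alone contributes.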